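The source may report more compounds than this note shows. Statements on the series, on what has been measured and on what is new or still open speak of the compounds shown alone.

Measured so far:
compound 1, `Cc1cc(/C=C/C#N)cc(C)c1Oc1cc(Nc2ccc(C#N)cc2)c(N)cc1C(=O)OCCC#N`: 0.2 h
compound 2, `Cc1cc(/C=C/C#N)cc(C)c1Oc1cc(Nc2ccc(C#N)cc2)c(N)cc1C(=O)NCCC(F)F`: 0.233 h

Both numbers come from an ADME assay on liver (Homo sapiens) for metabolic stability, read by LC-MS, using S9 fraction and NADPH, with a stated time of 45 min, tested at 1 uM; on this read-out lower numbers stand for a shorter-lived compound and higher numbers for a longer-lived compound. Compound 1 and compound 2 sit within the scatter of each other, the step being a 1.2-fold higher number from compound 1 to compound 2 (0.07 log units; within the scatter), so neither can be called longer- or shorter-lived on these data.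

Compound 3, `Cc1cc(/C=C/C#N)cc(C)c1Oc1cc(Nc2ccc(C#N)cc2)c(N)cc1C(=O)NN`, has not yet been measured. It differs from compound 1 in one place: aminoamino in place of 2-cyanoethoxy on a carbonyl carbon.

Among the measured compounds shown here, the only measured step that bears on this change is the one on the same carbonyl carbon, where (3,3-difluoropropyl)amino replaced 2-cyanoethoxy and gave a 1.2-fold higher number from compound 1 to compound 2 (0.07 log units; within the scatter), a step within the scatter. For the measured compounds named here, the aminoamino group is smaller than either of those, but no measured pair shows what such a group does here, so no step beyond the scatter is expected in this assay for compound 3. The estimated step from compound 1 to compound 3 is a 1.1-fold higher number from compound 1 to compound 3 (0.04 log units; within the scatter). Compound 3 is therefore expected to give about 0.22 h, within a range from 0.1 h to 0.5 h.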

Compound 3, half-life: 0.65 h
Beside the measured number, compound 3's estimate is 3.0-fold (0.47 log units) below it; measured number outside the range, above it.
By their numbers in this assay, from the lowest: compounds 1 and 2 (each within the scatter of the next); then compound 3.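

This carbonyl carbon can shift the half-life after all: in this assay aminoamino in place of 2-cyanoethoxy gives a 3.3-fold higher number from compound 1 to compound 3 (0.51 log units; beyond the scatter) and amino in place of 3,3-difluoropropyl on the amide-type nitrogen gives a 2.8-fold higher number from compound 2 to compound 3 (0.45 log units; beyond the scatter) as well. Among the compounds shown here, both steps are modest, but they are the first on this carbon to lie beyond the scatter, so the choice of group here is not neutral, as the earlier pair alone might have suggested. Nothing available explains why the number rises with aminoamino.

As far as these compounds go, it remains open whether the higher number goes with the terminal amino group or simply with a shorter group, which a plain primary amide or a carboxylic acid on this carbon could help separate. The compounds shown also share one core, so whether the step carries over to other cores is unknown.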